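The source may report more compounds than this note shows. Statements on the series, on what has been measured and on what is new or still open speak of the compounds shown alone.

Compound 1 `CC(C)c1cc(C(C)C)c(S(=O)(=O)n2c(C3(O)C=CC(=O)C=C3)cc3ccccc32)c(C(C)C)c1`: in a functional assay on HCT-116 cells (Homo sapiens) (a higher number here means that more compound is tolerated, a lower number that less compound is tolerated), compound 1 gives 550 nM.
Compound 2 `O=C1C=CC(O)(c2cc3ccccc3n2S(=O)(=O)c2ccc3ccccc3c2)C=C1`: compound 2 gives 370 nM.
Compound 3 `O=C1C=CC(O)(c2cc3ccccc3[nH]2)C=C1`: compound 3 gives 5130 nM.

Of these three numbers, compound 2 sits at the low end. Compound 1 lies within the usual scatter of compound 2, so the two cannot be told apart; compound 3, which carries no group on the ring nitrogen, lies well beyond the scatter on the high side. Compound 4 `COc1ccc(S(=O)(=O)n2c(C3(O)C=CC(=O)C=C3)cc3ccccc32)cc1` differs from compound 2 in one place: 4-methoxyphenyl in place of naphthalen-2-yl on a sulfonyl sulfur. Among the compounds with values here, with no measured pair of the same kind, the step is expected from the pattern that a sulfonyl aryl group keeps the number low. The step from compound 2 to compound 4 is expected to be a 1.9-fold higher number from compound 2 to compound 4 (0.28 log units; within the scatter), a modest rise. Compound 4 is therefore estimated at 700 nM, between 250 nM and 2000 nM.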

Compound 4, concentration lethal to 50% of the cells: 110 nM
Estimate against measurement, compound 4: 6.4-fold (0.80 log units) above; the measured number lies below the stated range.
By their numbers in this assay, from the lowest: compound 4; then compounds 2 and 1 (each within the scatter of the next); then compound 3.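

In this assay, placing 4-methoxyphenyl instead of naphthalen-2-yl on the sulfonyl sulfur gives a 3.4-fold lower number from compound 2 to compound 4 (0.53 log units; beyond the scatter). This shows that the number responds to the choice of aryl group at this place, and that a single aromatic ring can give a lower number here than two. Nothing measured explains why the number falls.

This change removes a ring and adds a methoxy group together, and the compounds shown cannot separate the two. They also do not show how an aryl group carrying an amine or a carboxylic acid would behave here.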